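From a difluoropiperidine to a tert-butylpiperazine

A few compounds are considered here, and "the series" means these few. Any claim that something is new, unique, unknown or untested is made for them only; others in the source may bear on it.

In a physicochemical assay for solubility, read by HPLC, using the shake flask method, in phosphate buffer, with a stated time of 20 h, at pH 6.5 (a lower number here means a less soluble compound, a higher number a more soluble compound), compound 3 (`Fc1cc(F)cc(-c2nc3c(N4CCC(CN5CCC(F)(F)CC5)CC4)nccc3[nH]2)c1`) gives < 5000 nM, which is a limit of the assay and not a number. Compound 1 (`CN1CCN(C2CCN(c3nccc4[nH]c(-c5cc(F)cc(F)c5)nc34)CC2)CC1`) gives 200000 nM, and compound 2 (`CN1CCN(C[C@@H]2CCCN(c3nccc4[nH]c(-c5cc(F)cc(F)c5)nc34)C2)CC1`) gives 145000 nM. Compound 4 (`CC(C)(C)N1CCN(CC2CCN(c3nccc4[nH]c(-c5cc(F)cc(F)c5)nc34)CC2)CC1`) carries 4-(tert-butyl)piperazin-1-yl in place of 4,4-difluoropiperidin-1-yl on a saturated chain carbon bound to a saturated ring carbon. Within the data shown here, the only measured step bearing on this is an at least 40-fold lower number from compound 1 to compound 3 (1.60 log units; beyond the scatter), where (4,4-difluoropiperidin-1-yl)methyl replaced 4-methylpiperazin-1-yl. Since the new change returns a piperazine, a large rise beyond the scatter is expected, read as an at least 12-fold higher number from compound 3 to compound 4 (1.07 log units; beyond the scatter). Compound 4 is expected at 60000 nM, with an estimated range of 12000 nM to 200000 nM.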

Compound 4, solubility: 185000 nM
Compound 4: the middle estimate sits 3.1-fold (0.49 log units) below what was measured; the measured number falls inside the stated range.
By their numbers in this assay, from the lowest: compounds 2, 4 and 1 (each within the scatter of the next). At a limit, below all of these: compound 3.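

Putting 4-(tert-butyl)piperazin-1-yl in place of 4,4-difluoropiperidin-1-yl at this place gives an at least 37-fold higher number from compound 3 to compound 4 (1.56 log units; beyond the scatter) in this assay. Compound 3 stands at a limit of the assay, not at a number: the limit of < 5000 nM in this assay, at which 1 of the 4 values shown sits. The step to (4-(tert-butyl)piperazin-1-yl)methyl in place of 4-methylpiperazin-1-yl on a saturated ring carbon is a 1.1-fold lower number from compound 1 to compound 4 (0.03 log units; within the scatter), so the two groups cannot be told apart here.

The compounds shown leave open whether an unsubstituted piperidin-1-yl or a morpholin-4-yl at this place would read like compound 3 or like compound 4.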